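The source may report more compounds than this note shows. Statements on the series, on what has been measured and on what is new or still open speak of the compounds shown alone.

- Compound 1 `N#CC1(c2cc(CCO)cc(-c3ccnc4[nH]nc(C(F)(F)F)c34)c2)CC1`: 17%
- Compound 2 `C[C@@H](O)Cc1cc(-c2ccnc3[nH]nc(C(F)(F)F)c23)cc(C2(C#N)CC2)c1`: 42%
- Compound 3 `C[C@H](O)Cc1cc(-c2ccnc3[nH]nc(C(F)(F)F)c23)cc(C2(C#N)CC2)c1`: 37%

These values come from an ADME assay on S9 fraction from liver (Rattus norvegicus) for metabolic stability, read by LC-MS, using NADPH, with a stated time of 60 min, tested at 10 uM; a lower number here means that less of the compound is left, a higher number that more of the compound is left. Compound 3 stands level with compound 2, the step being a number 5 percentage points lower from compound 2 to compound 3 (within the scatter), and clear of compound 1, the step being a number 20 percentage points higher from compound 1 to compound 3 (beyond the scatter).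

Compound 4 `CCC(O)Cc1cc(-c2ccnc3[nH]nc(C(F)(F)F)c23)cc(C2(C#N)CC2)c1` changes compound 3 by 1-hydroxypropyl in place of 1-hydroxyethyl on a saturated chain carbon bound to an aromatic carbon. Put another way, 2-hydroxypropyl gives way to 2-hydroxybutyl, and compound 4 is drawn without a defined stereocentre. The swap of configuration gave only a number 5 percentage points lower from compound 2 to compound 3 (within the scatter), so that missing definition should matter little.

The nearest guides are a number 25 percentage points higher from compound 1 to compound 2 (beyond the scatter) and a number 20 percentage points higher from compound 1 to compound 3 (beyond the scatter), where a methyl replaced a hydrogen on the carbon bearing the oxygen. Both steps were modest and went the same way. In compound 4, a chain that already has that branch only grows longer, so a repeat of those gains cannot be assumed. A small change that stays within the scatter is expected, with the estimate being a number 3 percentage points higher from compound 3 to compound 4 (within the scatter). Compound 4 is estimated at 40%, with an expected range of 24% to 56%.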

Compound 4, percent of the compound remaining: 17%
For compound 4 the middle estimate is 23 percentage points above the measured one, and the stated range ends above it.
By their numbers in this assay, from the lowest: compounds 1 and 4 (each within the scatter of the next); then compounds 3 and 2 (each within the scatter of the next).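

In this assay, going from 1-hydroxyethyl to 1-hydroxypropyl cancels the earlier gain, giving a number 20 percentage points lower from compound 3 to compound 4 (beyond the scatter) and a number 25 percentage points lower from compound 2 to compound 4 (beyond the scatter), while the comparison with the unbranched alcohol shows no change at the digits printed from compound 1 to compound 4 (within the scatter). The benefit of methyl in place of hydrogen on this saturated chain carbon therefore does not carry over to ethyl in place of hydrogen, so the outcome here depends on which group is added, not just on the presence of a branch. The undefined stereocentre of compound 4 hardly accounts for this, given a number 5 percentage points lower from compound 2 to compound 3 (within the scatter), and the reason for reading that step as a test of configuration alone is: the fact that compounds 2 and 3 differ only in the configuration as drawn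

The compounds shown leave open whether a longer chain such as 2-hydroxypentyl would fall further, or whether a cyclopropyl group on this carbon or a methyl ether in place of the hydroxyl would behave differently. They also leave open whether the two single stereoisomers of compound 4 differ from each other.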